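Second Chloro on the Shared Core: An Expected Gain

The source may hold more compounds than are shown below. What is called first, only, known or untested is meant among the compounds shown, and "the series" means these compounds.

Compound 1 `ClCc1ccc(Cn2cnc3c(Cl)ncnc32)cc1` was tested in a functional assay on Hs-578T cells (Homo sapiens) for cytotoxicity, read by sulforhodamine B assay, with a stated time of 48 h (on this read-out lower numbers stand for stronger inhibition of growth and higher numbers for weaker inhibition of growth), and gave 10200 nM, the highest of the two numbers recorded so far. Compound 2 `ClCc1cccc(Cn2cnc3c(Cl)nc(Cl)nc32)c1` gave in this assay 1990 nM; the two values stand apart beyond the usual scatter, with compound 2 at the lower number. Among the compounds with values here, compound 2 differs from compound 1 in more than one place, so no single step joins them. The pair shows only that a second chloro on the core can go together with a lower number. Compound 3 `ClCc1ccc(Cn2cnc3c(Cl)nc(Cl)nc32)cc1` has not yet been measured. It differs from compound 1 by chloro in place of hydrogen on an aromatic carbon. A step of a 3.4-fold lower number from compound 1 to compound 3 (0.53 log units; beyond the scatter) toward a lower number is expected, resting on compound 2 at 1990 nM. Compound 3 is therefore estimated to give 3000 nM, expected to fall between 1000 nM and 9000 nM.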

Compound 3, concentration for 50% growth inhibition: 2140 nM
For compound 3 the middle estimate is 1.4-fold (0.15 log units) above the measured one, within the range that was stated.
By their numbers in this assay, from the lowest: compounds 2 and 3 (each within the scatter of the next); then compound 1.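

Chloro in place of hydrogen on the aromatic carbon between two ring nitrogen atoms goes with a 4.8-fold lower number from compound 1 to compound 3 (0.68 log units; beyond the scatter) in this assay. Within the data shown here, the earlier pair differed in more than one place, so this is the first reading of this change on its own, and it shows that the lower number can arise without any other change to the molecule. Nothing given here accounts for the step.

How an amine, a methoxy group or a bromo atom on this same carbon would read remains open, so the compounds shown cannot say whether the step is particular to chloro. Also open, on these data alone, is whether the step would carry over to a core bearing a different group in place of the remaining chloro.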